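This account rests on a few compounds, and the source may have more. Where it says the series, first, only, none or still open, it means among the compounds named here.

Compound 1 `CCOc1cc(CN2CCC(NC(=O)c3cncc(C)c3)CC2)ccc1C` was measured in a physicochemical assay for solubility, in phosphate buffer, at pH 6.5; a higher number here means a more soluble compound, a lower number a less soluble compound. For compound 1 the result is only a limit of the assay, > 433 ug/mL, and so the position of compound 1 is known only as sitting at the upper edge of the measured values (the limit of > 433 ug/mL in this assay, at which 1 of the 2 values shown sits). Among the compounds with values here, compound 2 `CCOc1cc(CN2CCC(NC(=O)c3cncc(C)c3)CC2)cc(OCC)c1Cl` is the other measured compound, and in this assay compound 2 gives 216 ug/mL; no single-point step between compound 1 and compound 2 is recorded, so only their two values can be set side by side.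

Compound 3 `CCOc1cc(CN2CCC(NC(=O)c3ccc(N)nc3)CC2)ccc1C` has not yet been measured in this assay. It differs from compound 1 in one place: 6-aminopyridin-3-yl in place of 5-methylpyridin-3-yl on a carbonyl carbon. Because compound 1 already sits at the limit (the limit of > 433 ug/mL in this assay, at which 1 of the 2 values shown sits), a step from compound 1 to compound 3 is expected to be none beyond the scatter, with the result most likely again reported as a limit. Compound 3 is therefore expected to give about 450 ug/mL, within a range of 220 ug/mL to 900 ug/mL, a step that the limit leaves unreadable from compound 1 to compound 3.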

Compound 3, solubility: 375 ug/mL
The estimate for compound 3 lay 1.2-fold (0.08 log units) above the measured number; the range from low to high includes it.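

Within this assay, the exchange of 5-methylpyridin-3-yl for 6-aminopyridin-3-yl on a carbonyl carbon gives the first single-place step at this position: an at least 1.1-fold lower number from compound 1 to compound 3 (0.06 log units; that floor lies within the scatter). With the amino-bearing group in place, compound 3 gives a number that can be read (375 ug/mL) rather than a limit of the assay. That step is only a floor, and its true size cannot be read because the value of compound 1 is a limit and not a number: the limit of > 433 ug/mL in this assay, at which 1 of the 3 values shown sits.

The compounds shown leave open how far compound 3 truly lies from compound 1, and whether the same exchange would read alike on the core of compound 2. Also open, from the compounds shown here alone, is how a plain pyridin-3-yl, or a dimethylamino group or a carboxylic acid in place of the amino group, would behave at this position.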